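Cytotoxicity of nucleoside analogues: the methoxymethyl variant

A few compounds are considered here, and "the series" means these few. Any claim that something is new, unique, unknown or untested is made for them only; others in the source may bear on it.

Measured so far in a functional assay on Huh-7 cells (Homo sapiens) for cytotoxicity, read by MTT assay, with a stated time of 3 days; on this read-out lower numbers stand for higher toxicity in this test and higher numbers for lower toxicity in this test:
compound 1 `CSCc1ncnc2c1ncn2[C@@H]1O[C@H](CO)[C@@H](O)[C@H]1O` gives > 100000 nM, a limit of the assay.
compound 2 `OC[C@H]1O[C@@H](n2cnc3c(Cn4cccn4)ncnc32)[C@H](O)[C@@H]1O` gives > 250000 nM, also a limit of the assay.

For the measured compounds named here, compound 2 stands at a limit in this assay, and the one further value shown, that of compound 1, is a limit as well, at the limit of > 100000 nM in this assay, at which 1 of the 2 values shown sits. The step that the two limits leave unreadable from compound 1 to compound 2 is therefore unreadable from the two limits, and nothing about its size can be taken from it.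

Compound 3 `COCc1ncnc2c1ncn2[C@@H]1O[C@H](CO)[C@@H](O)[C@H]1O` differs from compound 2 by methoxy in place of 1H-pyrazol-1-yl on a saturated chain carbon bound to an aromatic carbon. Going by the values given here, the only measured step that bears on this change is a step that the two limits leave unreadable from compound 1 to compound 2, whose size the two limits hide. No readable step is available, so there is no basis to expect a shift in this assay beyond the scatter in either direction; compound 3 is instead expected to sit at a limit of the assay, as both measured compounds do.

For compound 3 the estimate in this assay is 150000 nM, with a range from 50000 nM to 500000 nM, so that the expected step of an at least 1.6-fold lower number from compound 2 to compound 3 (0.22 log units; that floor lies within the scatter) is essentially none.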

Compound 3, half-maximal cytotoxic concentration: > 100000 nM
Compound 3 ended at the assay's limit; the forecaster's own chance of this, stated with the estimate: 85%; the middle value lies beyond the limit too.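

In this assay compound 3 gives > 100000 nM, a limit of the assay. For the compounds shown here, no step among compound 1, compound 2 and compound 3 can be read; all three values are limits. The compounds shown leave open whether methylsulfanyl, 1H-pyrazol-1-yl and methoxy differ at all in this assay, and by how much.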